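The source may hold more compounds than are shown below. What is called first, only, known or untested is meant among the compounds shown, and "the series" means these compounds.

In a functional assay on A549 cells (Homo sapiens) for inhibition, read by sulforhodamine B assay (on this read-out higher numbers stand for weaker inhibition of growth and lower numbers for stronger inhibition of growth), compound 3 (`Cc1ccc2[nH]c(-c3ccc(-c4ccc(-c5ccccc5)cc4)cc3)nc2c1`) gives 3630 nM. Compound 1 (`COc1ccc(-c2ccc(-c3ccc(-c4nc5cc(C)ccc5[nH]4)cc3)cc2)cc1OC`) gives 2100 nM, and the gap between them is a 1.7-fold higher number from compound 1 to compound 3 (0.24 log units; within the scatter). Compound 3 therefore sits level with compound 1 within the scatter, and far from the third measured compound.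

Compound 4 (`Cc1ccc2[nH]c(-c3ccc(-c4ccc(-c5ccc(OC(F)(F)F)cc5)cc4)cc3)nc2c1`) keeps all of compound 3 and changes one place: trifluoromethoxy in place of hydrogen on an aromatic carbon. In words, this is trifluoromethoxy in place of hydrogen on an aromatic carbon, para to a large group.

Two pieces of evidence bear on this change. The step between compound 1 and compound 3 is a change on the same outer ring, and it stays small. The other is compound 2 (`FC(F)(F)Oc1ccc(-c2ccc(-c3ccc(-c4nc5ccccc5[nH]4)cc3)cc2)cc1`), which already carries trifluoromethoxy and gives 38000 nM. However, compound 2 also lacks the methyl group on the core of compound 3, so its value does not isolate the effect of the new group. Among the compounds with values here, no measured step covers this exact change.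

The expectation therefore leans upward from compound 3, but stops well short of compound 2. The expected step is a 2.5-fold higher number from compound 3 to compound 4 (0.39 log units; beyond the scatter), a modest rise in the number, meaning weaker inhibition of growth. For compound 4 the estimate is 9000 nM, with an expected range of 2500 nM to 32000 nM.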

Compound 4, concentration for 50% growth inhibition: 3560 nM
Estimate against measurement, compound 4: 2.5-fold (0.40 log units) above, within the range that was stated.
By their numbers in this assay, from the lowest: compounds 1, 4 and 3 (each within the scatter of the next); then compound 2.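

In this assay the outer ring accepts trifluoromethoxy in place of hydrogen with no visible effect (a 1.0-fold lower number from compound 3 to compound 4 (0.01 log units; within the scatter)), and swapping 3,4-dimethoxyphenyl for 4-(trifluoromethoxy)phenyl on the same core also stays level (a 1.7-fold higher number from compound 1 to compound 4 (0.23 log units; within the scatter)), so the three outer rings on this methyl-bearing core cannot be told apart. Within the data shown here, the weak result of compound 2 therefore cannot be pinned on trifluoromethoxy: with that group held constant, adding methyl to the core gives a large change (an 11-fold lower number from compound 2 to compound 4 (1.03 log units; beyond the scatter)), the first single-place step in this set that lies beyond the scatter. Nothing available explains why the methyl matters so much or why the new group changes so little.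

Going by these compounds, whether the methyl has the same large effect with a phenyl or 3,4-dimethoxyphenyl outer ring remains open, since only the trifluoromethoxy pair isolates it. It is also open whether the outer ring stays this undemanding when it carries an amine or a carboxylic acid, groups unlike any of those shown here.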